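The source may report more compounds than this note shows. Statements on the series, on what has been measured and on what is new or still open speak of the compounds shown alone.

Working notes on the series. Compound 1 `Nc1ccccc1NC(=O)c1ccc(CSC(=S)N2CCN(Cc3ccccn3)CC2)cc1` carries a (pyridin-2-yl)methyl group on a saturated chain carbon bound to an amine nitrogen in a ring; compound 2 `CC1CCCCN1C(=S)SCc1ccc(C(=O)Nc2ccccc2N)cc1` and compound 3 `CN(Cc1ccncc1)C(=S)SCc1ccc(C(=O)Nc2ccccc2N)cc1` vary instead at the thiocarbonyl carbon. In a functional assay on A-375 cells (Homo sapiens) for antiproliferative activity, read by CCK-8 assay, with a stated time of 72 h, tested at 2 uM (a higher number here means a stronger effect of the compound at the concentration tested, a lower number a weaker effect), compound 1 gives 20.7%, compound 2 gives 42.5% and compound 3 gives 31.4%. Compound 1 thus stands lowest of the three numbers, separated from both others by more than the scatter. For the measured compounds named here, the only step measured so far, a number 11.1 percentage points lower from compound 2 to compound 3 (beyond the scatter), concerns the group on the thiocarbonyl carbon and says nothing about the ring on the saturated chain carbon. Compound 4 `Nc1ccccc1NC(=O)c1ccc(CSC(=S)N2CCN(Cc3ccccc3)CC2)cc1` differs from compound 1 by phenyl in place of pyridin-2-yl on a saturated chain carbon bound to an amine nitrogen in a ring. Going by the values given here, no measured step bears on this exchange, so no change beyond the scatter is expected, with the direction open. Compound 4 is therefore estimated at 24%, within a range of 10% to 40%. That estimate implies an expected step of a number 3.3 percentage points higher from compound 1 to compound 4 (within the scatter), staying within the scatter.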

Compound 4, a percentage reported as inhibition, at one concentration (the size of the read-out at that concentration, not a potency): 10.6%
For compound 4 the middle estimate is 13.4 percentage points above the measured one, and the stated range covers the measured number.
By their numbers in this assay, from the lowest: compound 4; then compound 1; then compound 3; then compound 2.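

In this assay the exchange gives a number 10.1 percentage points lower from compound 1 to compound 4 (beyond the scatter) and so shows that the ring on this saturated chain carbon affects the read-out, which the earlier step at the thiocarbonyl carbon could not show. The two rings differ only in that pyridin-2-yl has a ring nitrogen and a hydrogen-bond acceptor where phenyl has neither, and in this one pair the ring with the nitrogen holds the higher number. Nothing at hand explains the difference.

Open, as far as these compounds go, is whether the presence of a ring nitrogen is enough or its place in the ring also counts, which pyridin-3-yl on the same carbon would address. Also open, from the compounds shown here alone, is whether an aromatic ring is needed here at all, which a cyclohexyl group or a plain methyl would test.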